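Swapping the six-membered ring on the cyclohexyl analogue

The compounds below may be only part of what the source reports. "The series", "measured", "known", "first", "only" and "open" are said of these compounds alone.

Within the data shown here, compound 3 `CCN(CC)[C@H]1CC[C@H](NC(=O)c2c(-c3c(Cl)cccc3Cl)noc2CCC2OCCCO2)CC1` gives 87 nM in an in vitro assay on CHO-K cells with growth hormone secretagogue receptor type 1 (Homo sapiens) as the target (on this read-out higher numbers stand for weaker inhibition and lower numbers for stronger inhibition), the highest of the three numbers known here. Its nearest neighbour is compound 2 `CCN(CC)c1ccc(NC(=O)c2c(-c3c(Cl)cccc3Cl)noc2CCC2CCCO2)cc1` with 57 nM, a gap within the scatter; compound 1 `CCN(CC)c1ccc(NC(=O)c2c(-c3c(Cl)cccc3Cl)noc2CCC2OCCCO2)cc1` with 6 nM lies furthest away, and the step of a 15-fold higher number from compound 1 to compound 3 (1.16 log units; beyond the scatter) is beyond the scatter. Compound 4 `CCN(CC)[C@H]1CC[C@H](NC(=O)c2c(-c3c(Cl)cccc3Cl)noc2CCC2CCCO2)CC1` differs from compound 3 by a group of 5 heavy atoms (4 carbon, 1 oxygen; one five-membered non-aromatic ring with 1 hetero atom) in place of a group of 6 heavy atoms (4 carbon, 2 oxygen; one six-membered non-aromatic ring with 2 hetero atoms), on a saturated chain carbon, two bonds along the chain from an aromatic carbon. The same exchange has been measured once before, starting from compound 1, where it gave a 9.5-fold higher number from compound 1 to compound 2 (0.98 log units; beyond the scatter). Among the measured compounds shown here, that single step is the only guide, so a move of similar size toward weaker inhibition is expected, namely a 6.9-fold higher number from compound 3 to compound 4 (0.84 log units; beyond the scatter). Compound 4 is therefore estimated at 600 nM, with a likely range from 150 nM to 2500 nM.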

Compound 4, half-maximal inhibitory concentration: 194 nM
Beside the measured number, compound 4's estimate is 3.1-fold (0.49 log units) above it; the range from low to high includes it.
By their numbers in this assay, from the lowest: compound 1; then compounds 2 and 3 (each within the scatter of the next); then compound 4.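

The exchange for oxolan-2-yl still weakens inhibition when 4-(diethylamino)cyclohexyl sits on the amide nitrogen, with a 2.2-fold higher number from compound 3 to compound 4 (0.35 log units; beyond the scatter), but the size of the loss depends on the rest of the molecule: the same change on two cores in this assay, a 9.5-fold higher number (0.98 log units; beyond the scatter) from compound 1 to compound 2 and a 2.2-fold higher number (0.35 log units; beyond the scatter) from compound 3 to compound 4, 4.3-fold (0.63 log units) apart, beyond the scatter of two such steps. Likewise, 4-(diethylamino)cyclohexyl in place of 4-(diethylamino)phenyl still weakens inhibition with oxolan-2-yl present, with a 3.4-fold higher number from compound 2 to compound 4 (0.53 log units; beyond the scatter), and the size again differs: the same change on two cores in this assay, a 15-fold higher number (1.16 log units; beyond the scatter) from compound 1 to compound 3 and a 3.4-fold higher number (0.53 log units; beyond the scatter) from compound 2 to compound 4, 4.3-fold (0.63 log units) apart, beyond the scatter of two such steps. Across compounds 1 to 4, then, the two changes do not simply add up, as each costs less once the other is present.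

From the compounds shown here alone, it remains open whether this holds for other groups at this place on the chain, such as a plain cyclohexyl ring with no oxygen or an open methoxy chain. These four compounds also cannot say why the two changes depend on each other.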